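Sulfonyl substituent changes on a shared benzofuran-free core series

The compounds below may be only part of what the source reports. "The series", "measured", "known", "first", "only" and "open" are said of these compounds alone.

Compound 1 `CCN(CC)c1ccc2cc(C(=O)c3ccc(N4CCN(S(=O)(=O)c5ccc([N+](=O)[O-])cc5)CC4)cc3)oc2c1` in a functional assay on MCF7 cells (Homo sapiens) for cytotoxicity, read by MTT assay, with a stated time of 48 h (a lower number here means a stronger inhibitor, a higher number a weaker inhibitor), gives > 40000 nM, which is a limit of the assay.
Compound 2 `CCN(CC)c1ccc2cc(C(=O)c3ccc(N4CCN(S(=O)(=O)c5ccc(Br)c(F)c5)CC4)cc3)oc2c1` in this assay gives 2270 nM.
Compound 3 `CCN(CC)c1ccc2cc(C(=O)c3ccc(N4CCN(S(=O)(=O)c5ccc(C)cc5)CC4)cc3)oc2c1` in this assay gives > 40000 nM, which is a limit of the assay.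

Compound 3 stands at the top edge of what this assay reports: the limit of > 40000 nM in this assay, at which 2 of the 3 values shown sit. Only compound 2 yields a number. The measured steps run an at least 17-fold lower number from compound 1 to compound 2 (1.24 log units; beyond the scatter) and an at least 17-fold higher number from compound 2 to compound 3 (1.24 log units; beyond the scatter), while a step that the two limits leave unreadable from compound 1 to compound 3.

Compound 4 `CCN(CC)c1ccc2cc(C(=O)c3ccc(N4CCN(S(C)(=O)=O)CC4)cc3)oc2c1` differs from compound 3 in one place: methyl in place of 4-methylphenyl on a sulfonyl sulfur. Among the measured compounds shown here, the steps that bear on this are the two that exchange one aryl group for another on the same sulfonyl sulfur, from compound 1 to compound 2 and from compound 2 to compound 3; both were large. For the measured compounds named here, no measured step removes the aryl ring altogether, so the guidance is indirect. Two of the three measured compounds sit at the limit, and compound 3 is one of them. Compound 4 is therefore expected to remain at or near that limit, with a number no higher from compound 3 to compound 4 (the limit leaves the size open) as the expected step. The estimate for compound 4 is 40000 nM, with a range from 10000 nM to 200000 nM.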

Compound 4, half-maximal inhibitory concentration: > 40000 nM
Compound 4: a limit, no number; the forecaster's own chance of this, stated with the estimate: 65%; the middle value lies on the limit itself.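

Methyl in place of 4-bromo-3-fluorophenyl on the sulfonyl sulfur gives an at least 17-fold higher number from compound 2 to compound 4 (1.24 log units; beyond the scatter), so a step that removes the aryl ring altogether also leaves no measurable number in this series. Compound 4 adds a sulfonyl substituent without a ring to the aryl-bearing compound 1 and compound 3 at the limit, and the 4-bromo-3-fluorophenyl group of compound 2 remains the only substituent shown that gives a number rather than a limit. The steps from compound 3 to compound 4 and from compound 1 to compound 4 join two limits and cannot be read, so any difference among these three compounds stays hidden, and the series now reads: the limit of > 40000 nM in this assay, at which 3 of the 4 values shown sit.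

Still open, as far as these compounds go, is whether the activity of compound 2 depends on bromine, on fluorine or on both, which a phenyl ring carrying bromine alone or fluorine alone on the sulfonyl sulfur would help to separate. Also open, from the compounds shown here alone, is whether a ring without aromatic character, such as cyclohexyl, or a longer alkyl chain on that sulfur would give a number in this assay.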